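A few compounds are considered here, and "the series" means these few. Any claim that something is new, unique, unknown or untested is made for them only; others in the source may bear on it.

Compounds 1 to 3 share one core and differ only in the group on a saturated ring carbon. In a physicochemical assay for lipophilicity, at pH 7.4 (a lower number here means a more polar compound, a higher number a more lipophilic compound), compound 1 `CNC(=O)c1cc(C(=O)N[C@H]2[C@@H]3COC[C@@H]32)cc2c1OC[C@H]2c1cccnc1` gives 1.4, compound 2 `CNC(=O)c1cc(C(=O)N[C@H]2[C@@H]3COC[C@@H]32)cc2c1OC[C@H]2c1cccc(OC)c1` gives 3.2, and compound 3 `CNC(=O)c1cc(C(=O)N[C@H]2[C@@H]3COC[C@@H]32)cc2c1OC[C@H]2c1ccc(F)cc1` gives 3.6, the highest of the three. Compound 4 `CNC(=O)c1cc(C(=O)N[C@H]2[C@@H]3COC[C@@H]32)cc2c1OC[C@H]2C1CCOCC1` carries oxan-4-yl in place of 4-fluorophenyl on a saturated ring carbon. Going by the values given here, no measured step makes this exact swap. The closest guides are a number 2.20 log units higher from compound 1 to compound 3 (beyond the scatter) and a number 0.40 log units higher from compound 2 to compound 3 (beyond the scatter). Compound 1, whose pyridin-3-yl ring holds a hetero atom, is the better guide, since oxan-4-yl also has one. The expected change in this assay is large and downward: a number 1.70 log units lower from compound 3 to compound 4 (beyond the scatter). For compound 4 the estimated value is 1.9, within a range of 1.4 to 2.4.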

Compound 4, distribution coefficient: 2.1
Beside the measured number, compound 4's estimate is 0.20 log units below it, and the stated range covers the measured number.
By their numbers in this assay, from the lowest: compound 1; then compound 4; then compound 2; then compound 3.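

Swapping in oxan-4-yl, the only non-aromatic ring at this saturated ring carbon so far, gives a number 1.50 log units lower from compound 3 to compound 4 (beyond the scatter) and a number 1.10 log units lower from compound 2 to compound 4 (beyond the scatter) in this assay. Pyridin-3-yl is also a six-membered ring with one hetero atom, yet oxan-4-yl gives a number 0.70 log units higher from compound 1 to compound 4 (beyond the scatter) against it, so two such rings can differ beyond the scatter. Nothing measured here explains these differences. Still open, going by these compounds, is whether piperidin-4-yl, which carries an amine, or a carboxylic acid at this carbon would fall under compound 1 in this assay or rise above it.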